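Cytotoxicity on THP-1 cells: amine substituent series

The compounds below may be only part of what the source reports. "The series", "measured", "known", "first", "only" and "open" are said of these compounds alone.

Measured so far in an ADME assay on THP-1 cells (Homo sapiens) for cytotoxicity; on this read-out higher numbers stand for lower toxicity in this test and lower numbers for higher toxicity in this test:
- compound 1 `c1ccc(-c2nc3ccccn3c2NCC2CC2)nc1`: 19400 nM
- compound 2 `c1ccc(-c2nc3ccccn3c2NC2CCOC2)nc1`: > 50000 nM
- compound 3 `c1ccc(-c2nc3ccccn3c2NC2CCNC2)nc1`: > 50000 nM

Within the data shown here, compound 1 is the only member with a number in this assay. For compound 2 the value is a limit of the assay, not a number. For compound 3 the value is likewise a limit of the assay. Compound 3 therefore sits at the top of what this assay reports, on the line where two of the three results fall (the limit of > 50000 nM in this assay, at which 2 of the 3 values shown sit); its step from compound 2 cannot be read, a step that the two limits leave unreadable from compound 2 to compound 3.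

The next step goes to compound 4 `c1ccc(CNc2c(-c3ccccn3)nc3ccccn23)cc1`. The change is benzyl in place of pyrrolidin-3-yl on a nitrogen on an aromatic ring. Of the measured steps, an at least 2.5-fold higher number from compound 1 to compound 3 (0.41 log units; beyond the scatter) bears most directly on it, since it is the reverse exchange at the same nitrogen; an at least 2.5-fold higher number from compound 1 to compound 2 (0.41 log units; beyond the scatter) points the same way. Both heterocyclic amines raised the number beyond the scatter relative to the cyclopropylmethyl of compound 1, and benzyl, like cyclopropylmethyl, carries no donor or acceptor. The expectation for compound 4 is thus a number somewhat below the limit, an estimated step of an at least 2.2-fold lower number from compound 3 to compound 4 (0.35 log units; beyond the scatter).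

Compound 4 is estimated at 22000 nM, with a range from 8000 nM to 50000 nM.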

Compound 4, half-maximal cytotoxic concentration: > 50000 nM
Compound 4 ended at the assay's limit; the forecaster's own chance of this, stated with the estimate: 35%; middle value at least 2.2-fold (0.35 log units) from the limit.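

In this assay compound 4 gives > 50000 nM, which is a limit of the assay and not a number. Benzyl, with 0 hydrogen-bond donors and 0 hydrogen-bond acceptors, reaches the same line as oxolan-3-yl and pyrrolidin-3-yl, so a group on this nitrogen needs no hetero atom to get there: the limit of > 50000 nM in this assay, at which 3 of the 4 values shown sit. Phenyl in place of cyclopropyl on the saturated chain carbon gives an at least 2.5-fold higher number from compound 1 to compound 4 (0.41 log units; beyond the scatter), which leaves compound 1 as the only member with a number.

From the compounds shown here alone, the steps among compound 2, compound 3 and compound 4 cannot be read, so any order among them stays unknown. Also open, going by these compounds, is whether a longer chain such as phenylethyl on this nitrogen would stay at the limit or fall back towards compound 1.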